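Cyclopropyl to thiophen-3-yl on a fused pyrazolopyridine core

The source may hold more compounds than are shown below. What is called first, only, known or untested is meant among the compounds shown, and "the series" means these compounds.

Compound 1, `OCCc1cc2nn(-c3ccccc3)cc2cn1`, in a functional assay on K562 cells (Homo sapiens) for inhibition, read by fluorescence, with a stated time of 72 h (on this read-out higher numbers stand for weaker inhibition of growth and lower numbers for stronger inhibition of growth), gives > 100000 nM, which is a limit of the assay and not a number.
Compound 2, `c1ccc(-n2cc3cnc(C4CC4)cc3n2)cc1`, in this assay gives 60500 nM.

Compound 2 holds the only real number shown; the other value is a limit (the limit of > 100000 nM in this assay, at which 1 of the 2 values shown sits). Among the compounds with values here, the step of an at least 1.6-fold lower number from compound 1 to compound 2 (0.21 log units; that floor lies within the scatter) is the sole measured step, and because it rests on that limit of > 100000 nM in this assay, at which 1 of the 2 values shown sits, its floor lies within the scatter, so it tells little about direction.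

Compound 3, `c1ccc(-n2cc3cnc(-c4ccsc4)cc3n2)cc1`, differs from compound 2 by thiophen-3-yl in place of cyclopropyl on an aromatic carbon. Within the data shown here, no measured step exchanges one ring for another at this place, so there is no direct precedent. With only a within-scatter step to draw on, the estimate for compound 3 is a number near that of compound 2, a step of a 1.7-fold lower number from compound 2 to compound 3 (0.24 log units; within the scatter) expected to sit largely within the scatter. Compound 3 is therefore estimated at 35000 nM in this assay, with a range from 8000 nM to 100000 nM.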

Compound 3, concentration for 50% growth inhibition: 8300 nM
Beside the measured number, compound 3's estimate is 4.2-fold (0.62 log units) above it, within the range that was stated.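

In this assay, this place on the shared core now shows a clear effect of the group it carries: thiophen-3-yl in place of cyclopropyl gives stronger inhibition of growth (a 7.3-fold lower number from compound 2 to compound 3 (0.86 log units; beyond the scatter)). The earlier pair could not show this, since its step stayed within the scatter. Thiophen-3-yl in place of 2-hydroxyethyl also gives a step beyond the scatter (an at least 12-fold lower number from compound 1 to compound 3 (1.08 log units; beyond the scatter)), but its true size stays unknown, and only a floor can be given: the limit of > 100000 nM in this assay, at which 1 of the 3 values shown sits.

Within the data shown here, only one aromatic ring has been seen at this place, so the result cannot separate the effect of an aromatic ring in general from that of thiophen-3-yl itself. On these data alone, how a thiophen-2-yl ring, an amine or a carboxylic acid would behave here remains open.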